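Series notes: from compound 3 to compound 4

This account rests on a few compounds, and the source may have more. Where it says the series, first, only, none or still open, it means among the compounds named here.

Compound 1 `Nc1nc2ccc(C3CCCCC3)cc2s1` gives > 10 mg/kg in a functional assay on the whole organism with Rattus norvegicus as the target (a higher number here means that more compound is needed for the effect, a lower number that less compound is needed), which is a limit of the assay and not a number.
Compound 2 `N=c1sc2cc(OC(F)(F)F)ccc2n1CCS(N)(=O)=O` gives 6 mg/kg in this assay.
Compound 3 `N=c1sc2cc(OC(F)(F)F)ccc2n1CCO` gives 8 mg/kg in this assay.

Of the two numbers shown, compound 3 holds the higher, and the step of a 1.3-fold higher number from compound 2 to compound 3 (0.12 log units; within the scatter) lies within the scatter. The remaining value, that of compound 1, is a limit (the limit of > 10 mg/kg in this assay, at which 1 of the 3 values shown sits).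

Compound 4 `CN(C)CCn1c(=N)sc2cc(OC(F)(F)F)ccc21` differs from compound 3 by dimethylamino in place of hydroxy on a saturated chain carbon, two bonds along the chain from an aromatic nitrogen. Among the compounds with values here, the only measured step at this place on the chain is a 1.3-fold higher number from compound 2 to compound 3 (0.12 log units; within the scatter), which did not move the number beyond the scatter; no measured step exchanges hydroxy for dimethylamino. The expectation for compound 4 is therefore no step beyond the scatter, no change at the digits printed from compound 3 to compound 4 (within the scatter). Compound 4 is estimated at 8 mg/kg, with a range from 4 mg/kg to 16 mg/kg.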

Compound 4, dose for half-maximal effect: 2.3 mg/kg
For compound 4 the middle estimate is 3.5-fold (0.54 log units) above the measured one, outside the stated range (below it).
By their numbers in this assay, from the lowest: compound 4; then compounds 2 and 3 (each within the scatter of the next). At a limit, above all of these: compound 1.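

In this assay this chain position now responds beyond the scatter: dimethylamino in place of hydroxy lowers the number (a 3.5-fold lower number from compound 3 to compound 4 (0.54 log units; beyond the scatter)), and dimethylamino in place of sulfamoyl lowers it as well (a 2.6-fold lower number from compound 2 to compound 4 (0.42 log units; beyond the scatter)). Hydroxy and sulfamoyl stay within the scatter of each other, so among the three groups shown at this place only dimethylamino stands apart. Nothing shown accounts for these steps.

Still open, going by these compounds, is whether the lower number follows the amine nitrogen or the larger group. A primary amine, a pyrrolidine or a longer chain ending in dimethylamino would bear on this.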